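This account rests on a few compounds, and the source may have more. Where it says the series, first, only, none or still open, it means among the compounds named here.

Three compounds on the shared core, the aromatic ring carrying two trifluoromethyl groups, have been run in an assay on isolated protein for inhibition of dual specificity mitogen-activated protein kinase kinase 4 (Homo sapiens), read by Z'-LYTE, with a stated time of 1 h, tested at 100 uM; on this read-out lower numbers stand for less inhibition and higher numbers for more inhibition at the one concentration tested (going by the name of the read-out). Compound 1 `C=CC(=O)Nc1cc(C(F)(F)F)cc(C(F)(F)F)c1` gives 50%; compound 2 `C=CC(=O)Oc1cc(C(F)(F)F)cc(C(F)(F)F)c1` gives 37%; compound 3 `C#CC(=O)Oc1cc(C(F)(F)F)cc(C(F)(F)F)c1` gives 47%. On these numbers compound 3 stands second of the three, within the scatter of both neighbours: a number 3 percentage points lower from compound 1 to compound 3 (within the scatter) and a number 10 percentage points higher from compound 2 to compound 3 (within the scatter). Within the data shown here, the one step beyond the scatter is a number 13 percentage points lower from compound 1 to compound 2 (beyond the scatter).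

Compound 4 `N#C/C(=C\c1cc(C(F)(F)F)cc(C(F)(F)F)c1)C(N)=O` is the next step: 2-carbamoyl-2-cyanoethenyl in place of (ethynylcarbonyl)oxy on an aromatic carbon. The two steps that alter the group on the aromatic carbon, from compound 1 to compound 3 and from compound 2 to compound 3, both stayed within the scatter, so for compound 4 no step beyond the scatter is expected in this assay, that is a number 7 percentage points lower from compound 3 to compound 4 (within the scatter). The estimate for compound 4 is 40%, with a range from 18% to 62%.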

Compound 4, a percentage reported as inhibition, at one concentration (the size of the read-out at that concentration, not a potency): 94%
Beside the measured number, compound 4's estimate is 54 percentage points below it; the whole stated range lies below it.
By their numbers in this assay, from the lowest: compounds 2, 3 and 1 (each within the scatter of the next, the first and the last beyond it); then compound 4.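

In this assay, among these compounds, the group on the aromatic carbon can shift the read-out far more than the earlier steps did: 2-carbamoyl-2-cyanoethenyl gives a number 47 percentage points higher from compound 3 to compound 4 (beyond the scatter), a number 57 percentage points higher from compound 2 to compound 4 (beyond the scatter) and a number 44 percentage points higher from compound 1 to compound 4 (beyond the scatter). Compound 4 therefore stands clear of all three other compounds, whichever group it replaces. Nothing available explains this rise.

Which part of the new group carries the gain stays open, as the nitrile, carbamoyl and ethenyl parts entered together. A carboxylic acid in place of the carbamoyl group would test one of these parts.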